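The compounds below may be only part of what the source reports. "The series", "measured", "known", "first", "only" and "open" are said of these compounds alone.

Working notes on a small set built on the core of compound 1, `CCOC(=O)C1=Cc2ccccc2OC1(OCc1cc(-c2ccc(OC)cc2)no1)C(F)(F)F`. In a functional assay on MCF7 cells (Homo sapiens) for inhibition, read by MTT assay, with a stated time of 24 h (on this read-out lower numbers stand for stronger inhibition and higher numbers for weaker inhibition), compound 1 gives only a limit, > 150000 nM. Compound 2, `O=C(O)C1=Cc2ccccc2OC1(OCc1cc(-c2ccc(F)cc2F)no1)C(F)(F)F`, is in this assay likewise a limit, > 150000 nM. Compound 3, `CCOC(=O)C1=Cc2ccccc2OC1(OCc1cn(-c2ccccc2)nn1)C(F)(F)F`, also returns a limit, > 150000 nM. Compound 1 therefore stands nowhere apart from the rest: the three values shown coincide at the limit of > 150000 nM in this assay, at which 3 of the 3 values shown sit, and no number sits beneath it from which a trend could be drawn.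

The next member, compound 4, `CCOC(=O)C1=Cc2ccccc2OC1(OCc1cc(-c2ccc(C)cc2)no1)C(F)(F)F`, differs from compound 1 in one place: methyl in place of methoxy on an aromatic carbon. Going by the values given here, no step between measured compounds covers this change, so its size cannot be read from the set. Compound 1 sits at the limit > 150000 nM, and nothing among the three values hints at entry into measurable range. The expected step is a step that the limit leaves unreadable from compound 1 to compound 4, none beyond the scatter, on the assumption that compound 4 stays where the series stands. Compound 4 is estimated at 200000 nM in this assay, with a range from 100000 nM to 500000 nM, and a limit is the most likely report.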

Compound 4, half-maximal inhibitory concentration: > 150000 nM
Compound 4 was reported as a limit; the forecaster's own chance of this, stated with the estimate: 85%; the middle value lies beyond the limit too.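

Compound 1 and compound 4 yield no readable step in this assay, as both are reported only as limits, and the set stays where it stood: the limit of > 150000 nM in this assay, at which 4 of the 4 values shown sit.

The compounds shown leave open whether any change on the shared core brings a member into measurable range in this assay.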